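Expected Shift After One Ring Exchange

This account rests on a few compounds, and the source may have more. Where it says the series, first, only, none or still open, it means among the compounds named here.

Compound 1 `Cn1nccc1-c1cc(C(F)(F)F)ccc1[C@H]1CCOc2cc(S(=O)(=O)Nc3ccncn3)ccc21`: 1.8
Compound 2 `O=S(=O)(Nc1nccs1)c1ccc2c(c1)OCC[C@H]2c1ccc(C(F)(F)F)cc1-n1ccnn1`: 2.3

Of the compounds shown here, two have so far been measured in a physicochemical assay for lipophilicity; a higher number here means a more lipophilic compound, a lower number a more polar compound. Compound 1 gives 1.8 there, and compound 2 gives 2.3. Of these two numbers compound 2 stands highest; its nearest neighbour is compound 1, whose value lies lower by an amount that goes beyond the usual scatter of repeated measurements.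

A third compound, compound 3 `Cc1nc(-c2cc(C(F)(F)F)ccc2[C@@H]2CCOc3cc(S(=O)(=O)Nc4nccs4)ccc32)co1`, has not yet been measured. It differs from compound 2 in one place: 2-methyl-1,3-oxazol-4-yl in place of 1H-1,2,3-triazol-1-yl on an aromatic carbon. Within the data shown here, no pair of measured compounds differing in a single spot is available, so the size of such a change cannot be read from earlier data. In this assay the estimated step of a number 0.60 log units higher from compound 2 to compound 3 (beyond the scatter) is expected to point upward and to exceed the scatter. Compound 3 is therefore expected to reach 2.9, within a range from 2.5 to 3.3.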

Compound 3, distribution coefficient: 2.9
Compound 3: middle estimate and measured number agree at the digits printed; the range from low to high includes it.
By their numbers in this assay, from the lowest: compound 1; then compound 2; then compound 3.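

In this assay, among these compounds, placing 2-methyl-1,3-oxazol-4-yl instead of 1H-1,2,3-triazol-1-yl gives a number 0.60 log units higher from compound 2 to compound 3 (beyond the scatter), the first change at a single place in this set. It shows that the read-out responds to what sits on this aromatic carbon, ortho to a large group and meta to a trifluoromethyl group, with the rest of the molecule unchanged. No separate measurement is available to explain the size of this step.

The exchange alters the ring and adds a methyl group together, so the compounds shown do not divide the step between those two parts. On these data alone, how this assay would respond to an amine, a carboxylic acid or a longer chain at this position also remains open.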